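Acetyl on the Ring Nitrogen: Compound 3 to Compound 4

The compounds below may be only part of what the source reports. "The series", "measured", "known", "first", "only" and "open" are said of these compounds alone.

Measured in an assay on isolated protein for inhibition of ribosomal protein S6 kinase alpha-2 (Homo sapiens), read by fluorescence, with a stated time of 20 min, tested at 10 uM; a higher number here means more inhibition at the concentration tested (going by the name of the read-out), a lower number less inhibition:
compound 1 `O=C1c2ccccc2C(=O)N1CNc1ccc(F)cc1`: 56.7%
compound 2 `CC(C)c1ccc(NCN2C(=O)c3ccccc3C2=O)cc1`: 46.5%
compound 3 `COc1ccc(NCN2C(=O)c3ccccc3C2=O)cc1`: 97.2%

Compound 3 stands highest of the three measured compounds, with steps of a number 40.5 percentage points higher from compound 1 to compound 3 (beyond the scatter) and a number 50.7 percentage points higher from compound 2 to compound 3 (beyond the scatter), both beyond the scatter; the remaining step, a number 10.2 percentage points lower from compound 1 to compound 2 (beyond the scatter), is the smallest change seen.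

Compound 4 `COc1ccc(N(CN2C(=O)c3ccccc3C2=O)C(C)=O)cc1` differs from compound 3 in one place: acetyl in place of hydrogen on a nitrogen on an aromatic ring. Among the measured compounds shown here, every measured step exchanges the group on the aromatic carbon, and none touches the nitrogen, so no measured step bears directly on this change. In this assay the account expects a loss for compound 4 of uncertain size, estimated as a number 37.2 percentage points lower from compound 3 to compound 4 (beyond the scatter). Compound 4 is expected to give about 60%, within 20% to 95%.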

Compound 4, a percentage reported as inhibition, at one concentration (the size of the read-out at that concentration, not a potency): 17.2%
The estimate for compound 4 lay 42.8 percentage points above the measured number, outside the stated range (below it).
By their numbers in this assay, from the lowest: compound 4; then compound 2; then compound 1; then compound 3.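

In this assay the first change made on the nitrogen on the aromatic ring gives a number 80 percentage points lower from compound 3 to compound 4 (beyond the scatter) and is the largest step in the series. This nitrogen, untouched by the earlier exchanges on the aromatic carbon, therefore matters strongly to the read-out, and acetyl in place of its hydrogen removes most of the inhibition. Nothing measured here explains the loss.

The compounds shown leave open whether the loss follows from the departing hydrogen or the entering acetyl, which a methyl on this nitrogen would help separate. Going by these compounds, whether acetyl costs as much alongside fluoro or isopropyl also stays open.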